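Replacing the benzyl group on the triazole with cyclohexyl

The source may hold more compounds than are shown below. What is called first, only, known or untested is meant among the compounds shown, and "the series" means these compounds.

Measured so far in a functional assay on RAW264.7 cells (Mus musculus) for inhibition, read by Griess assay, with stated times of 2 h and 24 h; a lower number here means a stronger inhibitor, a higher number a weaker inhibitor:
Compound 1 `COc1ccc([C@@H]2CC(=O)c3c(O)cc(OCc4cn(Cc5cccc(C)c5)nn4)cc3O2)cc1O` gives 17400 nM
Compound 2 `COc1ccc([C@@H]2CC(=O)c3c(O)cc(OCc4cn(Cc5cccc(C(F)(F)F)c5)nn4)cc3O2)cc1O` gives 19900 nM

Within the data shown here, only one other measured compound stands beside compound 2, and the two values lie within the scatter of each other, so neither can be ranked. Compound 3 `COc1ccc([C@@H]2CC(=O)c3c(O)cc(OCc4cn(C5CCCCC5)nn4)cc3O2)cc1O` carries a larger change: cyclohexyl in place of 3-(trifluoromethyl)benzyl on an aromatic nitrogen. In words, this is cyclohexyl in place of 3-(trifluoromethyl)benzyl on an aromatic nitrogen. Among the measured compounds shown here, only one measured step bears on it, a 1.1-fold higher number from compound 1 to compound 2 (0.06 log units; within the scatter), and that step exchanged only trifluoromethyl for methyl on an aromatic carbon. For the measured compounds named here, no measurement yet shows what happens when the benzyl group itself is replaced, so this evidence is indirect and the range must stay wide. The expected step is a 1.1-fold higher number from compound 2 to compound 3 (0.04 log units; within the scatter), which means no expected change beyond the scatter. For compound 3 the estimated value is 22000 nM, with an expected range from 8000 nM to 55000 nM.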

Compound 3, half-maximal inhibitory concentration: 15600 nM
Estimate against measurement, compound 3: 1.4-fold (0.15 log units) above; the range from low to high includes it.
By their numbers in this assay, from the lowest: compounds 3, 1 and 2 (each within the scatter of the next).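

In this assay, cyclohexyl in place of 3-(trifluoromethyl)benzyl on the aromatic nitrogen gives a 1.3-fold lower number from compound 2 to compound 3 (0.11 log units; within the scatter), and cyclohexyl in place of 3-methylbenzyl at the same place gives a 1.1-fold lower number from compound 1 to compound 3 (0.05 log units; within the scatter). The earlier step changed only a group on an aromatic carbon, whereas these two steps exchange the whole benzyl group, and its six-membered aromatic ring gives way to a non-aromatic ring of carbon only with no change beyond the scatter. Nothing measured here explains why the three values stay so close.

On these data alone, all three groups on this nitrogen hold a six-membered ring of carbon, so what an amine or a carboxylic acid would do at this place remains open. Also open, as far as these compounds go, is whether any group here can move the number beyond the scatter.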